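This account rests on a few compounds, and the source may have more. Where it says the series, first, only, none or still open, it means among the compounds named here.

In an ADME assay on BHK cells (Mesocricetus auratus) for cytotoxicity, read by MTT assay, with a stated time of 96 h (on this read-out lower numbers stand for higher toxicity in this test and higher numbers for lower toxicity in this test), compound 1 `CCNC(=S)Nc1cccc(C(F)(F)F)c1`, with ethyl, reaches only a limit of the assay, > 100000 nM. Compound 2 `Fc1ccc(NC(=S)Nc2cccc(C(F)(F)F)c2)cc1` gives 26000 nM, and compound 3 `Fc1ccccc1NC(=S)Nc1cccc(C(F)(F)F)c1` gives 54000 nM, the higher of the two exact numbers. The change to compound 4 `FC(F)(F)c1cccc(NC(=S)NCc2ccco2)c1` is (furan-2-yl)methyl in place of 2-fluorophenyl on an amide-type nitrogen. The nearest guides are an at least 3.8-fold lower number from compound 1 to compound 2 (0.58 log units; beyond the scatter), an at least 1.8-fold lower number from compound 1 to compound 3 (0.26 log units; that floor lies within the scatter), whose floor lies within the scatter, and a 2.1-fold higher number from compound 2 to compound 3 (0.32 log units; beyond the scatter). Going by the values given here, no measured compound carries a furan, so the comparison with ethyl is only a loose one. A modest rise is therefore expected in this assay, estimated as a 1.4-fold higher number from compound 3 to compound 4 (0.14 log units; within the scatter). Compound 4 is expected at 75000 nM, within an estimated range of 30000 nM to 150000 nM.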

Compound 4, half-maximal cytotoxic concentration: 48000 nM
Compound 4: middle estimate off by 1.6-fold (0.19 log units), on the high side; the measured number falls inside the stated range.
By their numbers in this assay, from the lowest: compounds 2, 4 and 3 (each within the scatter of the next, the first and the last beyond it). At a limit, above all of these: compound 1.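

In this assay, (furan-2-yl)methyl on the amide-type nitrogen cannot be told apart from either fluorophenyl group: the data give a 1.1-fold lower number from compound 3 to compound 4 (0.05 log units; within the scatter) and a 1.8-fold higher number from compound 2 to compound 4 (0.27 log units; within the scatter), both within the scatter. This position therefore accepts a five-membered aromatic ring with a hetero atom, carried on a saturated chain carbon, with no readable change from the six-membered rings. Against ethyl the data give an at least 2.0-fold lower number from compound 1 to compound 4 (0.31 log units; beyond the scatter), which is only a floor, as compound 1 stands at a limit: the limit of > 100000 nM in this assay, at which 1 of the 4 values shown sits.

Open, on these data alone, is whether a benzyl group, a longer chain or a carboxylic acid on this nitrogen would give a number in the same range. Also open, as far as these compounds go, is whether an unsubstituted phenyl group would fall with the fluorophenyl compounds.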